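The source may report more compounds than this note shows. Statements on the series, on what has been measured and on what is new or still open speak of the compounds shown alone.

The measured compounds:

Compound 1, `Cc1cc(Cl)c(S(C)(=O)=O)cc1C(=O)N=C(N)N`, gives 25 nM in a functional assay for inhibition of sodium/hydrogen exchanger (Oryctolagus cuniculus); on this read-out lower numbers stand for stronger inhibition and higher numbers for weaker inhibition.
Compound 2, `Cc1c(C(=O)N=C(N)N)cc(S(C)(=O)=O)c(Cl)c1C`, gives 58 nM in this assay.
Compound 3, `Cc1cc(C(F)(F)F)c(S(C)(=O)=O)cc1C(=O)N=C(N)N`, gives 37 nM in this assay.

Two of these pairs differ in a single place. Between compound 2 and compound 1 the change is hydrogen in place of methyl on an aromatic carbon, and it brought a 2.3-fold lower number from compound 2 to compound 1 (0.37 log units; beyond the scatter). Between compound 1 and compound 3 the change is trifluoromethyl in place of chloro on an aromatic carbon, and it brought a 1.5-fold higher number from compound 1 to compound 3 (0.17 log units; within the scatter). Compound 2 and compound 3 differ in more than one place, so the difference between their cores is not broken down here.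

Compound 4, `CS(=O)(=O)c1cc(C(=O)N=C(N)N)ccc1C(F)(F)F`, has not yet been measured. It differs from compound 3 by hydrogen in place of methyl on an aromatic carbon. Going by the values given here, this is the same kind of change as the one from compound 2 to compound 1, but its surroundings differ: in compound 2 the methyl that leaves sits ortho to a chloro group and ortho to a methyl group, meta to a group of 6 heavy atoms and meta to a methylsulfonyl group, whereas in compound 3 it sits ortho to a group of 6 heavy atoms, meta to a trifluoromethyl group and para to a methylsulfonyl group.

Among the compounds with values here, the only guide is the earlier step, so compound 4 is expected to show a 2.1-fold lower number from compound 3 to compound 4 (0.31 log units; beyond the scatter) in this assay, a step of about the same size as a 2.3-fold lower number from compound 2 to compound 1 (0.37 log units; beyond the scatter), with wider uncertainty because the surroundings are not the same. For compound 4 the estimate is 18 nM, with a range from 7 nM to 50 nM.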

Compound 4, half-maximal inhibitory concentration: 140 nM
Beside the measured number, compound 4's estimate is 7.8-fold (0.89 log units) below it, and the stated range ends below it.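

Taking away the methyl group of compound 3 does not repeat the earlier result: in this assay, hydrogen in place of methyl brought a 3.8-fold higher number from compound 3 to compound 4 (0.58 log units; beyond the scatter) and not a lower number. The same kind of change therefore moved the number in opposite directions on the two cores, and the gap between the two steps is larger than repeated measurements would explain: the same change on two cores in this assay, a 2.3-fold lower number (0.37 log units; beyond the scatter) from compound 2 to compound 1 and a 3.8-fold higher number (0.58 log units; beyond the scatter) from compound 3 to compound 4, 8.8-fold (0.94 log units) apart, beyond the scatter of two such steps. This shows that, for these two pairs, the effect of swapping methyl for hydrogen on an aromatic carbon cannot simply be carried from one core to another, but it does not show what sets the outcome, as the methyl groups that leave have different surroundings and two pairs cannot separate one feature of those surroundings from another.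

The compounds shown leave open how other groups would behave at the place on the core of compound 3 where the methyl group sits, such as an ethyl chain, a methoxy group or an amine. They also leave open how the step from methyl to hydrogen at that same place would run with chloro instead of trifluoromethyl on the ring.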